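The source may report more compounds than this note shows. Statements on the series, on what has been measured and on what is new or still open speak of the compounds shown alone.

Kinetic solubility series, measured in a physicochemical assay for solubility, read by chemiluminescence, measured as kinetic solubility; on this read-out lower numbers stand for lower solubility and higher numbers for higher solubility:

- compound 1 `COc1nn(C)c2nc(C)nc(NS(=O)(=O)c3cccc(Cl)c3Cl)c12`: >= 557000 nM, a limit
- compound 2 `COc1nc(NS(=O)(=O)c2cccc(Cl)c2Cl)c2c(OC)nn(C)c2n1`: 148000 nM
- compound 3 `CNc1nc(NS(=O)(=O)c2cccc(Cl)c2Cl)c2c(OC)nn(C)c2n1`: 376000 nM

Compound 3 has the higher of the two exact numbers, with a 2.5-fold higher number from compound 2 to compound 3 (0.40 log units; beyond the scatter). Going by these compounds, compound 1 gives only a limit, so its true value remains open. Against that limit, the comparison reads an at least 1.4-fold lower number from compound 1 to compound 3 (0.17 log units; that floor lies within the scatter).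

The next compound is compound 4 `COc1nn(C)c2nc(NC(C)C)nc(NS(=O)(=O)c3cccc(Cl)c3Cl)c12`, which carries isopropyl in place of methyl on a nitrogen on an aromatic ring. Seen one bond further out, this is methylamino to isopropylamino.

Among the compounds with values here, no measured step changes the group on this nitrogen, so the evidence is indirect. The closest guides are the other single-group changes on the shared core: an at least 3.7-fold lower number from compound 1 to compound 2 (0.57 log units; beyond the scatter) and a 2.5-fold higher number from compound 2 to compound 3 (0.40 log units; beyond the scatter). Both are modest or only a little larger, which suggests a step of similar size here. The direction is less secure, but compound 3 at 376000 nM already stands high among the numbers in this assay, so a modestly lower number is the working expectation.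

The expected change is a 1.7-fold lower number from compound 3 to compound 4 (0.23 log units; within the scatter). For compound 4 the estimated value is 220000 nM, with an expected range of 90000 nM to 450000 nM.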

Compound 4, solubility: >= 551000 nM
Compound 4: a limit, no number; the forecaster's own chance of this, stated with the estimate: 7%; middle value at least 2.5-fold (0.39 log units) away from the limit.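

In this assay, within the data shown here, compound 4 gives only a limit, >= 551000 nM, which is the first reading for a change on this nitrogen, a nitrogen on an aromatic ring whose other neighbour is an aromatic carbon. Isopropyl in place of methyl here brings no measurable loss: the comparison reads an at least 1.4-fold higher number from compound 3 to compound 4 (0.16 log units; that floor lies within the scatter), so the order of these two compounds stays unsettled, while the comparison with the methoxy compound reads an at least 3.7-fold higher number from compound 2 to compound 4 (0.57 log units; beyond the scatter), so isopropylamino stands clearly apart from methoxy on an aromatic carbon. The step between compound 1 and compound 4 cannot be read, as each gives only a limit.

Still open, going by these compounds, is where the true value of compound 4 lies, and with it whether isopropyl in place of methyl moves the read-out beyond the scatter at all. Also open, on these data alone, is how this assay would read with a longer chain such as butyl on this nitrogen, or with a carboxylic acid carried on that chain.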